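This account rests on a few compounds, and the source may have more. Where it says the series, first, only, none or still open, it means among the compounds named here.

Measured so far:
Compound 1 `COc1ccc(CNC(=O)/C=C/c2coc3cc(OC)ccc3c2=O)cc1` gives 43000 nM in an ADME assay on HepG2 2.2.15 cells (Homo sapiens) for cytotoxicity, read by MTT assay, with stated times of 48 h and 9 days; on this read-out higher numbers stand for lower toxicity in this test and lower numbers for higher toxicity in this test.
Compound 2 `COc1ccc2c(=O)c(/C=C/C(=O)NCc3ccccc3)coc2c1` gives 376000 nM in this assay.
Compound 3 `COc1ccc2c(=O)c(/C=C/C(=O)NCc3ccc(C)cc3)coc2c1` gives 257000 nM in this assay.

Compound 3 stands second highest of the three numbers; it is close to compound 2, with a 1.5-fold lower number from compound 2 to compound 3 (0.17 log units; within the scatter), and well apart from compound 1, with a 6.0-fold higher number from compound 1 to compound 3 (0.78 log units; beyond the scatter). The next compound is compound 4 `COc1ccc2c(=O)c(/C=C/C(=O)Nc3ccccc3OC)coc2c1`, not yet measured in this assay. Its change from compound 3 is 2-methoxyphenyl in place of 4-methylbenzyl on an amide-type nitrogen.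

Going by the values given here, none of the measured steps makes exactly this change: they only swap the group on the aromatic ring of the benzyl part, keeping the benzyl itself. Still, two bear on it: an 8.7-fold higher number from compound 1 to compound 2 (0.94 log units; beyond the scatter) and a 6.0-fold higher number from compound 1 to compound 3 (0.78 log units; beyond the scatter) show that a methoxy on that ring goes with the lowest number of the three, while methyl and hydrogen go with high numbers that sit within the scatter of each other. Compound 4 brings a methoxy back, though on a 2-methoxyphenyl joined directly to the amide nitrogen rather than through a benzyl. A modest step downward from compound 3 is therefore expected, with wide uncertainty, a 2.1-fold lower number from compound 3 to compound 4 (0.33 log units; beyond the scatter). For compound 4 the estimate is 120000 nM, expected between 30000 nM and 400000 nM.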

Compound 4, half-maximal cytotoxic concentration: 1050000 nM
Beside the measured number, compound 4's estimate is 8.8-fold (0.94 log units) below it, and the stated range ends below it.
By their numbers in this assay, from the lowest: compound 1; then compounds 3 and 2 (each within the scatter of the next); then compound 4.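

In this assay, compound 4 is the first shown with a change at the amide-type nitrogen itself rather than on the ring of a benzyl group, and the number rises against all three earlier compounds (a 4.1-fold higher number from compound 3 to compound 4 (0.61 log units; beyond the scatter); a 2.8-fold higher number from compound 2 to compound 4 (0.45 log units; beyond the scatter); a 24-fold higher number from compound 1 to compound 4 (1.39 log units; beyond the scatter)). The number rises whichever benzyl group leaves, so this position can hold a group that gives the highest number of the four, which here means the lowest toxicity in this test. A methoxy therefore does not go with a low number in every setting: compound 1, with 4-methoxybenzyl, has the lowest number of the four, while compound 4, with 2-methoxyphenyl, has the highest. Nothing available here explains this difference.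

The compounds shown leave open how much of the rise goes with losing the benzyl group's link to the ring and how much with the methoxy, as 2-methoxyphenyl brings both changes at once, and a plain phenyl on the amide-type nitrogen would part the two. Also open, going by these compounds, is how a group of a different kind at this nitrogen, such as a longer chain ending in an amine, would read.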